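The source may report more compounds than this note shows. Statements on the series, on what has been measured and on what is new or still open speak of the compounds shown alone.

Measured in a functional assay on MGC-803 cells (Homo sapiens) for inhibition, read by MTT assay, with a stated time of 48 h; on this read-out lower numbers stand for stronger inhibition and higher numbers for weaker inhibition:
- compound 1 `C/C=C/C(=O)N(Cc1cccc(O)c1)c1cc(OC)c(OC)c(OC)c1`: 14100 nM
- compound 2 `COc1cc(NCc2cccc(O)c2)cc(OC)c1OC`: 57600 nM
- compound 3 `COc1ccc(CNc2cc(OC)c(OC)c(OC)c2)cc1F`: 39700 nM

Compound 1 gives the lowest number of the three in this assay; compound 3 comes nearest and compound 2 is furthest. Within the data shown here, the only step between compounds that differ in one place is a 4.1-fold higher number from compound 1 to compound 2 (0.61 log units; beyond the scatter), which concerns the amide-type nitrogen, not the benzylic ring. Compound 2 and compound 3 differ in the benzylic ring and their values sit within a small span of each other, but that pair is not a single-place step and is read only as two values.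

Compound 4 `C/C=C/C(=O)N(Cc1ccc(OC)c(N)c1)c1cc(OC)c(OC)c(OC)c1` is not yet measured. The change from compound 1 is 3-amino-4-methoxyphenyl in place of 3-hydroxyphenyl on a saturated chain carbon bound to an amide-type nitrogen. Among the measured compounds shown here, no measured step touches this position in the amide series, so no step beyond the scatter is expected in this assay, in either direction. For compound 4 the estimate in this assay is 12000 nM, with a range of 4000 nM to 40000 nM, which amounts to an expected step of a 1.2-fold lower number from compound 1 to compound 4 (0.07 log units; within the scatter).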

Compound 4, half-maximal inhibitory concentration: 150 nM
Beside the measured number, compound 4's estimate is 80-fold (1.90 log units) above it, and the stated range ends above it.
By their numbers in this assay, from the lowest: compound 4; then compound 1; then compounds 3 and 2 (each within the scatter of the next).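

In this assay the aryl group on a saturated chain carbon bound to an amide-type nitrogen proves a strong handle on the read-out: 3-amino-4-methoxyphenyl in place of 3-hydroxyphenyl gives a 94-fold lower number from compound 1 to compound 4 (1.97 log units; beyond the scatter) in the amide series. This step is far larger than the only earlier one, the change on the nitrogen (a 4.1-fold higher number from compound 1 to compound 2 (0.61 log units; beyond the scatter)), so the aryl group counts for more here than that earlier step could suggest. No evidence on hand explains the size of this step.

The amino and methoxy groups enter together, and the hydroxy group leaves in the same step, so the shift cannot be assigned to any one of them; 3-aminophenyl and 3-hydroxy-4-methoxyphenyl at the same place would separate them. Also open, as far as these compounds go, is whether 3-amino-4-methoxyphenyl has a similar effect with hydrogen in place of (prop-1-en-1-yl)carbonyl on the nitrogen.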